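Notes on a larger substituent on the nitrogen

A few compounds are considered here, and "the series" means these few. Any claim that something is new, unique, unknown or untested is made for them only; others in the source may bear on it.

In a functional assay on DU-145 cells (Homo sapiens) for cytotoxicity, read by trypan blue exclusion, with a stated time of 96 h (a higher number here means a weaker inhibitor, a lower number a stronger inhibitor), compound 1 `COc1cc(OC)c(/C=C/S(=O)(=O)Cc2ccc(OC)c([N+](=O)[O-])c2)c(OC)c1` gives 2500 nM, compound 2 `COc1cc(OC)c(/C=C/S(=O)(=O)Cc2ccc(OC)c(N)c2)c(OC)c1` gives 4 nM and compound 3 `COC(=O)[C@H](C)Nc1cc(CS(=O)(=O)/C=C/c2c(OC)cc(OC)cc2OC)ccc1OC` gives 750 nM, the middle of the three numbers. Amino in place of nitro is a large step, a 630-fold lower number from compound 1 to compound 2 (2.80 log units; beyond the scatter). The only measured substitution on that nitrogen is also large, a 190-fold higher number from compound 2 to compound 3 (2.27 log units; beyond the scatter). Compound 4 `COC(=O)C(Nc1cc(CS(=O)(=O)/C=C/c2c(OC)cc(OC)cc2OC)ccc1OC)c1ccccc1` carries methoxycarbonyl)(benzyl in place of 1-(methoxycarbonyl)ethyl on a nitrogen on an aromatic ring, (methoxycarbonyl)(benzyl in place of 1-(methoxycarbonyl)ethyl on a nitrogen on an aromatic ring). Among the measured compounds shown here, no measured step swaps one such substituent for another, so the evidence is thin. In this assay only a small rise, probably within the scatter, is expected: a 1.3-fold higher number from compound 3 to compound 4 (0.12 log units; within the scatter). The estimated value for compound 4 is 1000 nM, with an expected range of 200 nM to 5000 nM.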

Compound 4, half-maximal inhibitory concentration: 75 nM
Estimate against measurement, compound 4: 13-fold (1.12 log units) above; the measured number lies below the stated range.
By their numbers in this assay, from the lowest: compound 2; then compound 4; then compound 3; then compound 1.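

In this assay the identity of the substituent on this nitrogen matters, not only its presence: the entering group, with one six-membered aromatic ring of carbon only, recovers much of the activity lost on substitution (a 10-fold lower number from compound 3 to compound 4 (1.00 log units; beyond the scatter)). It still falls short of the free amino group (a 19-fold higher number from compound 2 to compound 4 (1.27 log units; beyond the scatter)), while remaining well ahead of nitro (a 33-fold lower number from compound 1 to compound 4 (1.52 log units; beyond the scatter)). No measurement shown here explains this recovery. Open, on these data alone, is whether a carboxylic acid in place of the methyl ester, or a plain benzyl on that nitrogen, keeps this level.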